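Removing one methyl from the amine of compound 2

A few compounds are considered here, and "the series" means these few. Any claim that something is new, unique, unknown or untested is made for them only; others in the source may bear on it.

Compound 2 `CN(C)C/C=C(\c1cccnc1)c1ccccc1Br` is examined in an in vivo functional assay on the whole organism (brain) for inhibition of Norepinephrine transporter (Rattus norvegicus) (on this read-out lower numbers stand for an effect already at smaller amounts and higher numbers for an effect only at larger amounts of compound), where compound 2 gives 37 umol/kg. Among the compounds with values here, this is the lowest of the two numbers measured so far; the nearest is compound 1 `CN(C)C/C=C(/c1ccccc1)c1cccnc1`, which in this assay gives 107 umol/kg. Within the data shown here, the one measured step between them, a 2.9-fold lower number from compound 1 to compound 2 (0.46 log units; beyond the scatter), concerns a bromo in place of hydrogen on an aromatic carbon and says nothing about the amine.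

Compound 3 `CNC/C=C(\c1cccnc1)c1ccccc1Br` keeps the bromo and the rest of the core of compound 2 and differs only at the amine: hydrogen in place of methyl on an amine nitrogen. Among the measured compounds shown here, no measured step touches this position, so the expectation for this assay rests on the number of compound 2 alone and carries a wide range. The step is expected to be a 1.5-fold lower number from compound 2 to compound 3 (0.17 log units; within the scatter), that is, no change beyond the scatter or a modest move to a lower number. Compound 3 is therefore expected to give about 25 umol/kg in this assay, within a range from 8 umol/kg to 80 umol/kg.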

Compound 3, dose for half-maximal effect: 20 umol/kg
Beside the measured number, compound 3's estimate is 1.3-fold (0.10 log units) above it; the range from low to high includes it.
By their numbers in this assay, from the lowest: compounds 3 and 2 (each within the scatter of the next); then compound 1.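

Within the data shown here, until now no measured step touched the amine, and here hydrogen in place of methyl on an amine nitrogen gives a 1.9-fold lower number from compound 2 to compound 3 (0.27 log units; within the scatter) in this assay. Dimethylamino and methylamino therefore cannot be told apart on this read-out, and with the bromo and the rest of the core held constant, the second methyl on this nitrogen is not required to keep the effect at the level of compound 2. No available evidence accounts for how this exchange reads, so the step stands as an observation without an explanation.

The compounds shown leave open how far the amine can be changed beyond this single methyl, for instance to an unsubstituted amino group, to an ethyl group on the nitrogen or to a longer chain in its place. They also leave open whether dimethylamino to methylamino reads the same way without the bromo, or with a different halogen such as chloro in its place on the aromatic carbon.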